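Quinone Amines: Swapping a Phenyl for a Heptyl Chain

A few compounds are considered here, and "the series" means these few. Any claim that something is new, unique, unknown or untested is made for them only; others in the source may bear on it.

This account follows two related compounds built on the same quinone core and asks what a single change in the side chain might do to their effect on skin cells. Compound 1 `CC(C)(C)C1=CC(=O)C=C(NCc2ccccc2)C1=O` was tested in an ADME assay on HaCaT cells (Homo sapiens) for cytotoxicity, read by MTT assay, with a stated time of 72 h (on this read-out lower numbers stand for stronger inhibition and higher numbers for weaker inhibition), and gave 21000 nM. Compound 2 `CC(C)(C)C1=CC(=O)C(NCc2ccccc2)=CC1=O` is a close relative with the same groups arranged differently on the core; in this assay compound 2 gave 28000 nM. Compound 1 has the lowest of the two numbers, yet its gap to compound 2 lies within the scatter, so the two cannot be told apart. Compound 3 `CCCCCCCCNC1=CC(=O)C=C(C(C)(C)C)C1=O` has not been measured. It differs from compound 1 in one place: heptyl in place of phenyl on a saturated chain carbon bound to an amine nitrogen. Within the data shown here, with no measured step to lean on, only a modest shift is expected, toward a somewhat lower number, and the step from compound 1 to compound 3 is estimated at a 1.4-fold lower number from compound 1 to compound 3 (0.15 log units; within the scatter). For compound 3 in this assay, the expected value is 15000 nM, with a likely range from 5000 nM to 45000 nM.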

Compound 3, half-maximal inhibitory concentration: 30000 nM
Compound 3: the middle estimate sits 2.0-fold (0.30 log units) below what was measured; measured number inside the range.
By their numbers in this assay, from the lowest: compounds 1, 2 and 3 (each within the scatter of the next).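

At this place, on a saturated chain carbon bound to an amine nitrogen, heptyl in place of phenyl gives a 1.4-fold higher number from compound 1 to compound 3 (0.15 log units; within the scatter) in this assay. This first measured step at the position shows that, for this pair, an open chain with no ring can stand where the aromatic ring stood without a difference this read-out can separate from ordinary scatter. Nothing measured here bears on the reason for this result.

Still open, going by these compounds, is whether a shorter chain such as ethyl, a much longer chain, or a chain ending in an amine or a carboxylic acid would move the number beyond the scatter. Also open, on these data alone, is whether heptyl in place of phenyl would give a similar result on the arrangement of the shared core seen in compound 2.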